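This account rests on a few compounds, and the source may have more. Where it says the series, first, only, none or still open, it means among the compounds named here.

Measured compounds:
compound 1, `COc1cnc(-c2ccccn2)nc1N1CCCCCC1`, 690 nM
compound 2, `COc1cnc(-c2ccccn2)nc1NC(C)c1ccccc1`, 660 nM

Both values come from a functional assay on RAW264.7 cells (Mus musculus), with a stated time of 3 days; on this read-out higher numbers stand for weaker inhibition and lower numbers for stronger inhibition. Compound 1 gives the higher of the two numbers, but its gap to compound 2 lies within the scatter, so the two compounds cannot be told apart on this read-out.

Compound 3, `COc1cnc(-c2ccccn2)nc1N1CCCC1`, has not yet been measured. It differs from compound 1 in one place: pyrrolidin-1-yl in place of azepan-1-yl on an aromatic carbon. No comparable change between measured compounds exists here, so the expectation rests on the two values alone. Compound 3 is expected to give 900 nM in this assay, with a range of 300 nM to 3000 nM. The estimated step of a 1.3-fold higher number from compound 1 to compound 3 (0.12 log units; within the scatter) is small, barely beyond the scatter if at all.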

Compound 3, half-maximal inhibitory concentration: 150 nM
Beside the measured number, compound 3's estimate is 6.0-fold (0.78 log units) above it; the measured number lies below the stated range.
By their numbers in this assay, from the lowest: compound 3; then compounds 2 and 1 (each within the scatter of the next).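

In this assay, among the compounds shown here, the change to pyrrolidin-1-yl on this aromatic carbon gives a 4.6-fold lower number from compound 1 to compound 3 (0.66 log units; beyond the scatter) and so shows that the position responds to the ring placed there, which the earlier compounds could not show. The step is modest but beyond the scatter, and it goes with a five-membered non-aromatic ring replacing a seven-membered one. No measurement shown here accounts for this step. The compounds shown leave open how a piperidin-1-yl or morpholin-4-yl ring would read at this position. Going by these compounds, an open-chain dimethylamino group is equally open.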